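Swapping a Pyrazinyl for an Acetyl on the Ring Nitrogen

The compounds below may be only part of what the source reports. "The series", "measured", "known", "first", "only" and "open" are said of these compounds alone.

Of the compounds shown here, three have been measured in an ADME assay on RAW264.7 cells (Mus musculus) for cytotoxicity, read by MTT assay, with a stated time of 72 h, tested at 50 ug/mL; on this read-out lower numbers stand for less inhibition and higher numbers for more inhibition at the one concentration tested (going by the name of the read-out). Compound 1 `O=C(c1nc2cc(Cl)ccc2s1)N1CCN(c2cnccn2)CC1` gives 54.9%, compound 2 `CN1CCN(C(=O)c2nc3ccccc3s2)CC1` gives 52.1%, and compound 3 `O=C(c1nc2cc(C(F)(F)F)ccc2s1)N1CCN(c2cnccn2)CC1` gives 28.1%. Compound 3 thus stands lowest of the three, beyond the scatter of both others. Going by the values given here, the only single-point step among the measured compounds is a number 26.8 percentage points lower from compound 1 to compound 3 (beyond the scatter), a trifluoromethyl in place of chloro on an aromatic carbon.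

Compound 4 `CC(=O)N1CCN(C(=O)c2nc3cc(C(F)(F)F)ccc3s2)CC1` keeps the trifluoromethyl of compound 3 and changes only the group on the amine nitrogen in the ring: acetyl in place of pyrazin-2-yl on an amine nitrogen in a ring. Among the compounds with values here, no measured step touches this position, so nothing in the numbers speaks directly to it. Compound 1 and compound 2 differ both in the group on the ring nitrogen and in the group on the aromatic carbon, yet their values lie within the scatter of each other, which gives no sign that the ring-nitrogen group moves the read-out much. The expected change is therefore a number 1.9 percentage points higher from compound 3 to compound 4 (within the scatter), a step within the scatter. The estimate for compound 4 is 30%, with a range from 15% to 48%.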

Compound 4, a percentage reported as inhibition, at one concentration (the size of the read-out at that concentration, not a potency): 20.2%
Estimate against measurement, compound 4: 9.8 percentage points above; low and high end bracket the measured number.
By their numbers in this assay, from the lowest: compounds 4 and 3 (each within the scatter of the next); then compounds 2 and 1 (each within the scatter of the next).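

Going by these compounds alone, with the trifluoromethyl held fixed, this pair gives the first direct reading at the amine nitrogen in the ring: in this assay, acetyl in place of pyrazin-2-yl gives a number 7.9 percentage points lower from compound 3 to compound 4 (within the scatter). The exchange is a large one on paper, since a six-membered aromatic ring with 6 heavy atoms leaves and an open group with 3 heavy atoms enters, yet the step stays within the scatter, so this one change at this position does not visibly move the read-out. Nothing available accounts for this result.

The compounds shown leave open whether a carboxylic acid, a primary amine or a longer chain on this nitrogen would give a step beyond the scatter. They also leave open whether the same exchange would read alike with chloro in place of trifluoromethyl on the aromatic carbon.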